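Two Chlorines in Place of an Amine on the Sulfonyl Aryl

The source may hold more compounds than are shown below. What is called first, only, known or untested is meant among the compounds shown, and "the series" means these compounds.

Compound 1 `CC1CCN(C2CCN(S(=O)(=O)c3cccc(N)c3)CC2)CC1` is the weakest of the three measured compounds in a functional assay on DLD-1 cells (Homo sapiens) for antiproliferative activity, read by CellTiter-Glo, with a stated time of 72 h; a higher number here means a weaker inhibitor, a lower number a stronger inhibitor: compound 1 gives 3400 nM, while compound 2 `CC1CCN(C2CCN(S(=O)(=O)c3cccc(-c4ccccc4F)c3)CC2)CC1` gives 10 nM and compound 3 `CC1CCN(C2CCN(S(=O)(=O)c3cccc(-c4ccc5ccccc5c4)c3)CC2)CC1` gives 2 nM. The two measured steps from compound 1, a 340-fold lower number from compound 1 to compound 2 (2.53 log units; beyond the scatter) and a 1700-fold lower number from compound 1 to compound 3 (3.23 log units; beyond the scatter), both replace the amino with an aryl group. Compound 4 `CC1CCN(C2CCN(S(=O)(=O)c3cc(Cl)cc(Cl)c3)CC2)CC1` differs from compound 1 in another way: 3,5-dichlorophenyl in place of 3-aminophenyl on a sulfonyl sulfur. For the measured compounds named here, no measured step swaps the amino for halogens, so the expectation rests only loosely on those large gains. Compound 4 is expected to improve on compound 1 by a 6.8-fold lower number from compound 1 to compound 4 (0.83 log units; beyond the scatter), and its estimated value in this assay is 500 nM, within a range from 80 nM to 3000 nM.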

Compound 4, half-maximal inhibitory concentration: 3400 nM
For compound 4 the middle estimate is 6.8-fold (0.83 log units) below the measured one; measured number above the stated range.
By their numbers in this assay, from the lowest: compound 3; then compound 2; then compounds 1 and 4 (each within the scatter of the next).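

Going to 3,5-dichlorophenyl on the sulfonyl sulfur gives no change at the digits printed from compound 1 to compound 4 (within the scatter) in this assay, even though the hydrogen-bond donor and acceptor of 3-aminophenyl are gone. The large gains of compound 2 and compound 3 are therefore not shared by every replacement of the 3-aminophenyl group. Nothing available explains this result. The compounds shown leave open whether a single chlorine or a methoxy group would read the same as the two chlorines, and whether a pyridine ring could stand in for the 2-fluorophenyl of compound 2.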